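The source may report more compounds than this note shows. Statements on the series, on what has been measured and on what is new or still open speak of the compounds shown alone.

Working notes on the series. In a functional assay on A549 cells (Homo sapiens) for antiproliferative activity, read by MTT assay, with a stated time of 48 h (on this read-out lower numbers stand for stronger inhibition and higher numbers for weaker inhibition), compound 1 `COc1ccc(/C=C/c2cc(OC)cc(OC)c2/C=C/C(=O)c2cccc(Br)c2)cc1` gives 8.1 ug/mL and compound 2 `COc1ccc(/C=C/c2cc(OC)cc(OC)c2/C=C/C(=O)c2cccc(Cl)c2)cc1` gives 5.6 ug/mL with a 1.4-fold lower number from compound 1 to compound 2 (0.16 log units; within the scatter) as the step between them. Compound 3 `COc1ccc(/C=C/c2cc(OC)cc(OC)c2/C=C/C(=O)c2ccc(C)c(C)c2)cc1` stands lowest of the three at 0.1 ug/mL in this assay and is reached by two large steps: an 81-fold lower number from compound 1 to compound 3 (1.91 log units; beyond the scatter) and a 56-fold lower number from compound 2 to compound 3 (1.75 log units; beyond the scatter) on the same carbonyl carbon.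

The next change, to compound 4 `COc1ccc(/C=C/c2cc(OC)cc(OC)c2/C=C/C(=O)c2ccc(-c3ccccc3)cc2)cc1` is 4-phenylphenyl in place of 3,4-dimethylphenyl on a carbonyl carbon and puts 4-phenylphenyl in place of 3,4-dimethylphenyl on that carbonyl carbon. Within the data shown here, no measured compound carries 4-phenylphenyl, so the two large steps show only that this place can move the number strongly. Among the measured compounds shown here, with compound 3 at 0.1 ug/mL as the lowest number so far, a move upward seems more likely than a further fall, though its size is poorly constrained. The expected step is a 15-fold higher number from compound 3 to compound 4 (1.18 log units; beyond the scatter) in this assay as a rise beyond the scatter. For compound 4 the estimate is 1.5 ug/mL with an expected range from 0.3 ug/mL to 8 ug/mL in this series.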

Compound 4, half-maximal inhibitory concentration: 4.6 ug/mL
The estimate for compound 4 lay 3.1-fold (0.49 log units) below the measured number; low and high end bracket the measured number.
By their numbers in this assay, from the lowest: compound 3; then compounds 4, 2 and 1 (each within the scatter of the next).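

In this assay the low number of compound 3 does not carry over to 4-phenylphenyl on the carbonyl carbon, with a 46-fold higher number from compound 3 to compound 4 (1.66 log units; beyond the scatter) as a large rise. The other two steps, a 1.2-fold lower number from compound 2 to compound 4 (0.09 log units; within the scatter) and a 1.8-fold lower number from compound 1 to compound 4 (0.25 log units; within the scatter), both lie within the scatter, so compound 4 cannot be told apart from compound 1 or compound 2, and among the four groups on this carbonyl carbon only 3,4-dimethylphenyl stands apart. Nothing available on these compounds accounts for this separation. 

As far as these compounds go, whether the low number needs both methyl groups of 3,4-dimethylphenyl or a single methyl group would suffice stays open. Also open, from the compounds shown here alone, is how an amine or a carboxylic acid on that ring would read, and whether the separation holds on a different core.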